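Naphthalen-2-yl in place of 2-methoxyphenyl on a short-lived compound

The source may hold more compounds than are shown below. What is called first, only, known or untested is meant among the compounds shown, and "the series" means these compounds.

In an ADME assay on S9 fraction from liver (Mus musculus, strain ICR/CD-1) for metabolic stability, read by LC-MS, using NADPH, with a stated time of 5 min, tested at 2 uM (on this read-out higher numbers stand for a longer-lived compound and lower numbers for a shorter-lived compound), compound 1 (`COc1ccccc1-c1cccc(S(=O)(=O)N2CCC(N3CCC(C)CC3)CC2)c1`) gives 0.25 h as the lower of the two numbers available. Compound 2 (`CC1CCN(C2CCN(S(=O)(=O)c3ccc(-c4ccccc4F)cc3)CC2)CC1`) gives 3.5 h and so stands above compound 1 by a gap beyond the usual scatter. Compound 3 (`CC1CCN(C2CCN(S(=O)(=O)c3cccc(-c4ccc5ccccc5c4)c3)CC2)CC1`) differs from compound 1 in one place: naphthalen-2-yl stands in place of 2-methoxyphenyl on an aromatic carbon, meta to a large group (naphthalen-2-yl in place of 2-methoxyphenyl on an aromatic carbon). Among the compounds with values here, no two measured compounds differ in one place only, so the data offer no direct guide to this step, and the number of compound 2 cannot be credited to any single group. In this assay a small rise no larger than the usual scatter is expected (a 2.0-fold higher number from compound 1 to compound 3 (0.30 log units; within the scatter)). Compound 3 is estimated at 0.5 h with an expected range from 0.15 h to 1.8 h in this read-out.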

Compound 3, half-life: 3.4 h
Beside the measured number, compound 3's estimate is 6.8-fold (0.83 log units) below it; measured number above the stated range.
By their numbers in this assay, from the lowest: compound 1; then compounds 3 and 2 (each within the scatter of the next).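

With this single change, this assay records a 14-fold higher number from compound 1 to compound 3 (1.13 log units; beyond the scatter). Within the data shown here, this is the first comparison that differs in one place only, and it shows that the group on this aromatic carbon, meta to a large group, can by itself set the half-life over a wide span while the rest of compound 1 stays the same. Nothing measured here accounts for the rise.

The change removes the methoxy oxygen and adds a second aromatic ring at once, so the compounds shown leave open which of the two carries the step. From the compounds shown here alone, a plain phenyl group at this place would separate them, and the effect of a 2-methylphenyl group, which keeps the substituent without the oxygen, also remains open.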